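A few compounds are considered here, and "the series" means these few. Any claim that something is new, unique, unknown or untested is made for them only; others in the source may bear on it.

Measured compounds:
compound 1, `O=C(Nc1cccc(S(=O)(=O)C2CCCC2)c1)c1cccnc1N1CCCCC1`: > 399 mL.min-1.g-1
compound 2, `CC(C)(C)NS(=O)(=O)c1cccc(NC(=O)c2ccc(NS(=O)(=O)C3(C)CC3)cc2N2CCC3(CC2)CC3)c1`: 90 mL.min-1.g-1

In an ADME assay on microsomes from liver (Mus musculus) for metabolic stability, read by LC-MS, with a stated time of 40 min, tested at 0.5 uM (on this read-out lower numbers stand for slow clearance and higher numbers for fast clearance), compound 1 gives > 399 mL.min-1.g-1, which is a limit of the assay and not a number. Its position is therefore fixed only at one end: the limit of > 399 mL.min-1.g-1 in this assay, at which 1 of the 2 values shown sits. Among the compounds with values here, compound 2, built on a different core, gives 90 mL.min-1.g-1 in this assay, a number well inside the measurable span, but no step connects compound 2 to compound 1, so the pair shows only these two readings.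

Compound 3, `O=C(Nc1cccc(S(=O)(=O)C2CCCC2)c1)c1cccnc1N1CCC2(CC1)CC2`, is not yet measured. It differs from compound 1 in one place: a group of 8 heavy atoms (7 carbon, 1 nitrogen; one three-membered non-aromatic ring of carbon only, one six-membered non-aromatic ring with 1 hetero atom) in place of a group of 6 heavy atoms (5 carbon, 1 nitrogen; one six-membered non-aromatic ring with 1 hetero atom), on an aromatic carbon. The new group sits on an aromatic carbon of a six-membered aromatic ring with one nitrogen, next to the ring nitrogen and ortho to a large group.

Within the data shown here, no measured step frames this change, so the expectation rests on compound 1 alone. Because compound 1 sits at the limit, (the limit of > 399 mL.min-1.g-1 in this assay, at which 1 of the 2 values shown sits), the account expects compound 3 to stay in the fast-clearance region, with any change from compound 1 to compound 3 most likely no larger than the scatter, as an at least 1.2-fold lower number from compound 1 to compound 3 (0.09 log units; that floor lies within the scatter) conveys. Compound 3 is estimated at 320 mL.min-1.g-1, in the range 120 mL.min-1.g-1 to 900 mL.min-1.g-1, with a fair chance that this assay again reports only a limit.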

Compound 3, intrinsic clearance in microsomes: > 399 mL.min-1.g-1
Compound 3: a limit, no number (the forecaster's own chance of this, stated with the estimate: 55%); at least 1.2-fold (0.09 log units) between middle value and limit.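

In this assay compound 3 gives > 399 mL.min-1.g-1, which is a limit of the assay and not a number. Compound 1 also reports only a limit, so no step between compound 1 and compound 3 can be read: the limit of > 399 mL.min-1.g-1 in this assay, at which 2 of the 3 values shown sit.

The compounds shown leave open how high the clearance of compound 1 and compound 3 really is, and whether replacing piperidin-1-yl with the group carrying the three-membered ring changes it at all.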